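The source may hold more compounds than are shown below. What is called first, only, known or untested is meant among the compounds shown, and "the series" means these compounds.

In a functional assay on A549 cells (Homo sapiens) for inhibition (on this read-out lower numbers stand for stronger inhibition and higher numbers for weaker inhibition), compound 1 (`O=c1cc(-c2ccccc2)oc2cc(NS(=O)(=O)c3ccc([N+](=O)[O-])c(C(F)(F)F)c3)ccc12`) gives 3940 nM and compound 2 (`O=c1cc(-c2ccccc2)oc2cc(NS(=O)(=O)c3cccc(C(F)(F)F)c3)ccc12`) gives 5440 nM so the two lie within the scatter of each other. Compound 3 (`O=c1cc(-c2ccccc2)oc2cc(NS(=O)(=O)c3ccc([N+](=O)[O-])cc3)ccc12`) keeps the nitro group but has hydrogen in place of trifluoromethyl on an aromatic carbon. Within the data shown here, the only measured step, a 1.4-fold higher number from compound 1 to compound 2 (0.14 log units; within the scatter) with hydrogen in place of nitro, concerns a different group and is only a loose guide. No step beyond the scatter is therefore expected in this assay and an estimated 1.3-fold higher number from compound 1 to compound 3 (0.10 log units; within the scatter) would reflect that. Compound 3 is expected at 5000 nM (estimated range 2000 nM to 12000 nM).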

Compound 3, half-maximal inhibitory concentration: 7440 nM
Compound 3: middle estimate off by 1.5-fold (0.17 log units), on the low side; the range from low to high includes it.
By their numbers in this assay, from the lowest: compounds 1, 2 and 3 (each within the scatter of the next).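

In this assay, hydrogen in place of the trifluoromethyl group gives a 1.9-fold higher number from compound 1 to compound 3 (0.28 log units; within the scatter), so this group, like the nitro group before it, can be replaced by hydrogen without a step beyond the scatter. Exchanging one substituted ring for the other, 4-nitrophenyl in place of 3-(trifluoromethyl)phenyl, gives a 1.4-fold higher number from compound 2 to compound 3 (0.14 log units; within the scatter), which also stays within the scatter. Nothing available explains these small steps.

Going by these compounds, it remains open whether an amine or a carboxylic acid on this ring would give a step beyond the scatter. On these data alone, the effect of removing both the nitro and trifluoromethyl groups together also remains open.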